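This account rests on a few compounds, and the source may have more. Where it says the series, first, only, none or still open, it means among the compounds named here.

Three compounds have numbers in an assay on T-REx-293 cells for inhibition of potassium channel subfamily T member 1 (Homo sapiens), read by patch clamp; a lower number here means a stronger inhibitor, a higher number a weaker inhibitor: compound 1 `Cc1ccnc(-c2noc([C@H](C)NC(=O)c3cc(C(F)(F)F)nn3C)n2)c1`, compound 2 `C[C@H](NC(=O)c1cc(C(F)(F)F)nn1C)c1nc(-c2ccccn2)no1` and compound 3 `C[C@H](NC(=O)c1cc(C(F)(F)F)nn1C)c1nc(-c2ccnc(N(C)C)c2)no1`. Compound 1 gives 4470 nM. Compound 3 gives 454 nM. For compound 2 the assay reports only a limit, > 30000 nM (the limit of > 30000 nM in this assay, at which 1 of the 3 values shown sits). Compound 3 thus stands lowest of the two numbers shown; the gap to the nearest is a 9.8-fold lower number from compound 1 to compound 3 (0.99 log units; beyond the scatter). Compound 4 `CO[C@H](C)c1cc(-c2noc([C@H](C)NC(=O)c3cc(C(F)(F)F)nn3C)n2)ccn1` carries 1-methoxyethyl in place of dimethylamino on an aromatic carbon. The measured steps that touch this ring are a 9.8-fold lower number from compound 1 to compound 3 (0.99 log units; beyond the scatter) and an at least 66-fold lower number from compound 2 to compound 3 (1.82 log units; beyond the scatter), both beyond the scatter, yet neither replaces dimethylamino with 1-methoxyethyl, so only a modest rise in the number is expected, a 3.3-fold higher number from compound 3 to compound 4 (0.52 log units; beyond the scatter). Compound 4 is therefore estimated at 1500 nM, with a range from 400 nM to 6000 nM.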

Compound 4, half-maximal inhibitory concentration: 778 nM
Beside the measured number, compound 4's estimate is 1.9-fold (0.29 log units) above it, and the stated range covers the measured number.
By their numbers in this assay, from the lowest: compounds 3 and 4 (each within the scatter of the next); then compound 1. At a limit, above all of these: compound 2.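

In this assay, the position next to the ring nitrogen holds 1-methoxyethyl in place of dimethylamino with no change beyond the scatter, a 1.7-fold higher number from compound 3 to compound 4 (0.23 log units; within the scatter), so a dimethylamino nitrogen is not required there. The gain over the methyl-bearing pyridine also remains with this group, a 5.7-fold lower number from compound 1 to compound 4 (0.76 log units; beyond the scatter). The step from the unsubstituted pyridine, an at least 38-fold lower number from compound 2 to compound 4 (1.58 log units; beyond the scatter), rests on a limit, not a number: the limit of > 30000 nM in this assay, at which 1 of the 4 values shown sits.

Still open, on these data alone, is how a methoxy group or a cyclic amine such as morpholine would read at this position. Also open, as far as these compounds go, is whether the other configuration of the 1-methoxyethyl stereocentre would read the same.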